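The compounds below may be only part of what the source reports. "The series", "measured", "known", "first", "only" and "open" are said of these compounds alone.

Measured compounds:
- compound 1, `CN(CC1=CC[C@H]2C[C@@H]1C2(C)C)Cc1ccccc1`: 15800 nM
- compound 2, `CN(CC1=CC[C@H]2C[C@@H]1C2(C)C)Cc1ccc(F)cc1`: 6310 nM

Both compounds were tested in an assay on HEK293 cells for displacement of a labelled ligand from C-X-C chemokine receptor type 3 (Homo sapiens); a lower number here means a stronger inhibitor, a higher number a weaker inhibitor. Compound 1 gives 15800 nM, and compound 2 gives 6310 nM, the lowest of the two numbers; its nearest neighbour is compound 1, and the step of a 2.5-fold lower number from compound 1 to compound 2 (0.40 log units; beyond the scatter) lies beyond the scatter.

Compound 3, `CN(CC1=CC[C@H]2C[C@@H]1C2(C)C)Cc1ccc(Cl)cc1`, has not yet been measured in this assay. It differs from compound 2 by chloro in place of fluoro on an aromatic carbon. Within the data shown here, no measured step changes fluoro for chloro, so the only step that bears on this position is the one that first introduced the fluoro, a 2.5-fold lower number from compound 1 to compound 2 (0.40 log units; beyond the scatter), which was modest and lowered the number. A halogen at this position therefore seems to be tolerated, but how a chloro compares with a fluoro there cannot be read from the data shown. Compound 3 is expected to give roughly 4000 nM, within a range of 1500 nM to 12000 nM, which corresponds to an estimated step of a 1.6-fold lower number from compound 2 to compound 3 (0.20 log units; within the scatter), a change that may well stay within the scatter.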

Compound 3, inhibition constant: 2510 nM
Compound 3: middle estimate off by 1.6-fold (0.20 log units), on the high side, within the range that was stated.
By their numbers in this assay, from the lowest: compound 3; then compound 2; then compound 1.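

In this assay, among these compounds, the earlier compounds showed only that a halogen at this place lowers the number, but the position now also separates one halogen from another, with a 2.5-fold lower number from compound 2 to compound 3 (0.40 log units; beyond the scatter) on exchanging fluoro for chloro. Measured against the hydrogen of the parent, the chloro gives a 6.3-fold lower number from compound 1 to compound 3 (0.80 log units; beyond the scatter) and so the larger of the two changes seen here on the aromatic carbon para to a large group, which places hydrogen, fluoro and chloro in one order across compound 1, compound 2 and compound 3, with every step beyond the scatter and compound 3 the strongest inhibitor of the three. The material at hand offers no measurement that would explain this order.

Whether the trend runs on at this place remains open, since bromo, iodo, methyl, trifluoromethyl and methoxy do not appear among these compounds, so the order rests on chloro, fluoro and hydrogen alone. From the compounds shown here alone, it is equally open whether a chloro placed elsewhere on the six-membered aromatic ring, or a second chloro on it, would give a lower or a higher number than compound 3 does.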